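The source may hold more compounds than are shown below. What is called first, only, known or untested is meant among the compounds shown, and "the series" means these compounds.

Measured so far in an ADME assay on HEK293 cells (Homo sapiens) for cytotoxicity, read by MTT assay, with a stated time of 48 h; on this read-out higher numbers stand for weaker inhibition and lower numbers for stronger inhibition:
- compound 1 `Cc1ccc(S(=O)(=O)/N=C(/CCNC2=CC(=O)c3ccccc3C2=O)Nc2cccc(C(F)(F)F)c2)cc1` gives 91500 nM
- compound 2 `COc1ccc(N/C(CCNC2=CC(=O)c3ccccc3C2=O)=N\S(=O)(=O)c2ccc(C)cc2)cc1OC` gives 60600 nM
- compound 3 `Cc1ccc(S(=O)(=O)/N=C(/CCNC2=CC(=O)c3ccccc3C2=O)NC(C)C)cc1` gives 71600 nM

Compound 2 carries the lowest number of the three, but the spread is small: a 1.5-fold lower number from compound 1 to compound 2 (0.18 log units; within the scatter) and a 1.2-fold higher number from compound 2 to compound 3 (0.07 log units; within the scatter) are both within the scatter, so the three compounds are not separated on this assay. Compound 4 `COc1ccc(N/C(CCNC2=C(Br)C(=O)c3ccccc3C2=O)=N\S(=O)(=O)c2ccc(C)cc2)cc1OC` is not yet measured. It differs from compound 2 in one place: bromo in place of hydrogen on a double-bonded ring carbon. Among the compounds with values here, none of the measured steps bears directly on this change; all three of them vary the group on the amine nitrogen, and the core is unchanged across compounds 1, 2 and 3. Those steps, a 1.5-fold lower number from compound 1 to compound 2 (0.18 log units; within the scatter), a 1.3-fold lower number from compound 1 to compound 3 (0.11 log units; within the scatter) and a 1.2-fold higher number from compound 2 to compound 3 (0.07 log units; within the scatter), were all within the scatter, which gives no evidence that a single-atom change moves this assay, and no evidence for a direction. The step of a 1.0-fold lower number from compound 2 to compound 4 (0.00 log units; within the scatter) is therefore expected to be none beyond the scatter. Compound 4 is estimated at 60000 nM, in the range 25000 nM to 150000 nM.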

Compound 4, half-maximal inhibitory concentration: 35300 nM
For compound 4 the middle estimate is 1.7-fold (0.23 log units) above the measured one, and the stated range covers the measured number.
By their numbers in this assay, from the lowest: compounds 4, 2, 3 and 1 (each within the scatter of the next, the first and the last beyond it).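

Within the data shown here, all the earlier steps varied the group on the amine nitrogen, while this one changes the shared core itself: bromo in place of hydrogen on a double-bonded ring carbon gives, in this assay, a 1.7-fold lower number from compound 2 to compound 4 (0.23 log units; within the scatter) and so does not separate the pair. One added bromine, on a carbon next to the ring atom that bears a large group, thus leaves this pair unresolved, as the amine nitrogen changes left compounds 1, 2 and 3. No measurement of any property is available to account for the size of this step.

On these data alone, whether chloro, methyl or an amine on the same ring carbon would give a step beyond the scatter remains open. Also open, as far as these compounds go, is whether bromo would give a step of similar size with the isopropyl or 3-(trifluoromethyl)phenyl group on the amine nitrogen.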